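Pyridin-2-yl Amide on a Shared Pyrazole Core

The source may report more compounds than this note shows. Statements on the series, on what has been measured and on what is new or still open speak of the compounds shown alone.

Measured so far:
compound 1, `Cc1ccc(C(=O)Nc2cc(-c3ccccc3)nn2-c2ccccc2)cc1`: 30 nM
compound 2, `O=C(Nc1cc(-c2ccccc2)nn1-c1ccccc1)c1cccc(Cl)c1`: 40 nM

In an assay on CHO cells with metabotropic glutamate receptor 5 (Homo sapiens) as the target (a higher number here means that more compound is needed for the effect, a lower number that less compound is needed), compound 1 gives 30 nM. In this assay compound 2 gives 40 nM, the higher of the two numbers, yet the step of a 1.3-fold higher number from compound 1 to compound 2 (0.12 log units; within the scatter) lies within the scatter, so the two compounds cannot be told apart on these numbers.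

Compound 3, `O=C(Nc1cc(-c2ccccc2)nn1-c1ccccc1)c1ccccn1`, has not been measured. It differs from compound 2 in one place: pyridin-2-yl in place of 3-chlorophenyl on a carbonyl carbon. For the measured compounds named here, the only measured step, a 1.3-fold higher number from compound 1 to compound 2 (0.12 log units; within the scatter), swaps one carbon-only six-membered ring for another on the carbonyl carbon and changes nothing beyond the scatter; it says little about a ring that brings in a hetero atom and a hydrogen-bond acceptor. Going by the values given here, no measured pair shows that change. For compound 3 a step of a 2.0-fold higher number from compound 2 to compound 3 (0.30 log units; within the scatter) is therefore expected, a modest move toward a higher number that may still fall inside the scatter, with a wide range because the data give no direct guide. Compound 3 is estimated at 80 nM, between 20 nM and 400 nM.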

Compound 3, half-maximal effective concentration: 290 nM
The estimate for compound 3 lay 3.6-fold (0.56 log units) below the measured number; measured number inside the range.
By their numbers in this assay, from the lowest: compounds 1 and 2 (each within the scatter of the next); then compound 3.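

In this assay, the carbonyl carbon proves sensitive to the ring it carries: pyridin-2-yl in place of 3-chlorophenyl gives a 7.3-fold higher number from compound 2 to compound 3 (0.86 log units; beyond the scatter), and pyridin-2-yl in place of 4-methylphenyl gives a 9.7-fold higher number from compound 1 to compound 3 (0.99 log units; beyond the scatter). Both steps lie beyond the scatter, whereas the exchange of one carbon-only ring for the other, a 1.3-fold higher number from compound 1 to compound 2 (0.12 log units; within the scatter), stays within it, so among these three compounds only the ring with a hetero atom and a hydrogen-bond acceptor stands apart at this position. No measurement at hand accounts for this rise, and the numbers alone do not say which feature of the pyridin-2-yl group lies behind it.

Still open, on these data alone, is whether the step belongs to the ring nitrogen as such or to where it stands in the ring, a question that pyridin-3-yl or pyridin-4-yl on the same carbonyl carbon would address. Also open, as far as these compounds go, is how this position would respond to a group without an aromatic ring, such as cyclohexyl or a short alkyl chain, and whether the same step would appear on a core other than the one shared here.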